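Removing the Acyl Group from a Ring Nitrogen

The source may hold more compounds than are shown below. What is called first, only, known or untested is meant among the compounds shown, and "the series" means these compounds.

Compound 2 `CC(=O)N1N=C(c2ccc(Cl)cc2)CC1c1cn(-c2ccccc2)nc1-c1ccc(Cl)c(Cl)c1` is one of two compounds tested in a functional assay on the whole organism (strain Wistar) for inhibition, with Rattus norvegicus as the target, read by paw edema, with stated times of 30 min and 120 min, at a dose of 50 mg/kg by the oral route (a higher number here means more inhibition at the dose given (going by the name of the read-out), a lower number less inhibition), where compound 2 gives 66.4%. Compound 1 `O=CN1N=C(c2ccc(Cl)cc2)CC1c1cn(-c2ccccc2)nc1-c1ccc(Cl)c(Cl)c1` gives 57.8% in this assay. On the numbers shown, compound 2 stands nearest compound 1, and the step of a number 8.6 percentage points higher from compound 1 to compound 2 (within the scatter) lies within the scatter, so the inhibition in this assay is level between the two. Compound 3 `Clc1ccc(C2=NNC(c3cn(-c4ccccc4)nc3-c3ccc(Cl)c(Cl)c3)C2)cc1` has not yet been measured. The change from compound 2 to compound 3 is hydrogen in place of acetyl on an amine nitrogen in a ring. Within the data shown here, the only measured step, a number 8.6 percentage points higher from compound 1 to compound 2 (within the scatter), alters the same carbonyl group and stayed within the scatter; no measured step removes the acetyl group entirely, so its contribution is unknown. The expectation is therefore a step of about a number 8.4 percentage points lower from compound 2 to compound 3 (within the scatter), not clearly beyond the scatter. Compound 3 is estimated at 58%, with a range from 40% to 72%.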

Compound 3, a percentage reported as inhibition, in the whole organism at one dose (the size of the read-out at that dose, not a potency): 48.4%
The estimate for compound 3 lay 9.6 percentage points above the measured number; the range from low to high includes it.
By their numbers in this assay, from the lowest: compounds 3, 1 and 2 (each within the scatter of the next, the first and the last beyond it).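

In this assay, among these compounds, hydrogen in place of acetyl on this amine nitrogen in a ring comes with a number 18 percentage points lower from compound 2 to compound 3 (beyond the scatter), the first step in this small set to clear the scatter. This shows that what sits on this nitrogen can affect the inhibition at the dose given, which the step between the two acylated compounds could not show. Hydrogen in place of formyl, however, comes with a number 9.4 percentage points lower from compound 1 to compound 3 (within the scatter), so compound 1 lies within the scatter of both other compounds, and only the acetyl group separates clearly from hydrogen.

Nothing measured here explains why the acetyl and formyl groups differ in this way.
Also open, from the compounds shown here alone, is whether a longer chain such as propanoyl, a benzoyl group, or a plain methyl group without a carbonyl would read like acetyl or like hydrogen at this nitrogen.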